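Working notes on ester variation within the series

The source may report more compounds than this note shows. Statements on the series, on what has been measured and on what is new or still open speak of the compounds shown alone.

Compound 1 `COC(=O)C1=C(C)NC(C)=C(C(=O)OC)C1c1cnc(SC)n1Nc1ccccc1` is the reference with both esters as methoxycarbonyl; in an assay on isolated protein (strain albino) for antagonist activity at Voltage-dependent L-type calcium channel subunit alpha-1C (Cavia porcellus) (a higher number here means a weaker inhibitor, a lower number a stronger inhibitor), compound 1 gives 3.54 nM. Compound 2 `COC(=O)C1=C(C)NC(C)=C(C(=O)OCCCc2ccccc2)C1c1cnc(SC)n1Nc1ccccc1` differs by phenethyl in place of hydrogen on a saturated chain carbon bound to an oxygen next to a carbonyl group; in this assay compound 2 gives 3.05 nM. That change reads as a 1.2-fold lower number from compound 1 to compound 2 (0.06 log units; within the scatter). Of the two numbers, that of compound 2 is the lower, though its gap to compound 1 is within the scatter, so no order between them can be claimed.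

Compound 3 `CCOC(=O)C1=C(C)NC(C)=C(C(=O)OCCCc2ccccc2)C1c1cnc(SC)n1Nc1ccccc1` is the next step: methyl in place of hydrogen on a saturated chain carbon bound to an oxygen next to a carbonyl group. Among the compounds with values here, the only measured step, a 1.2-fold lower number from compound 1 to compound 2 (0.06 log units; within the scatter), also altered an ester substituent and barely moved the number; it bears on the present change only loosely, as the methyl enters at the other ester. No step beyond the scatter is expected in this assay; the expected step is a 1.0-fold lower number from compound 2 to compound 3 (0.01 log units; within the scatter). Compound 3 is estimated at 3 nM in this assay, with a range from 1.2 nM to 7.5 nM.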

Compound 3, half-maximal inhibitory concentration: 2.54 nM
Estimate against measurement, compound 3: 1.2-fold (0.07 log units) above, and the stated range covers the measured number.
By their numbers in this assay, from the lowest: compounds 3, 2 and 1 (each within the scatter of the next).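

Within the data shown here, the methyl gives the first reading at the methoxycarbonyl ester, the ester left unchanged from compound 1 to compound 2, where methoxycarbonyl becomes ethoxycarbonyl. In this assay this reads as a 1.2-fold lower number from compound 2 to compound 3 (0.08 log units; within the scatter), so a change at this second ester, made with the phenethyl-bearing ester held fixed, also stays inside the scatter, and both single-place ester changes shown so far leave the number unresolved. No measurement available here accounts for the size of this step.

Going by these compounds, it remains open whether a longer chain such as butyl, or a chain ending in an amine or a carboxylic acid, would stay equally close to compound 2 at this position. Also open, on these data alone, is whether methoxycarbonyl to ethoxycarbonyl would read the same on compound 1, without the phenethyl group.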